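A few compounds are considered here, and "the series" means these few. Any claim that something is new, unique, unknown or untested is made for them only; others in the source may bear on it.

Measured compounds in an assay on CHO cells for antagonist activity at transient receptor potential cation channel subfamily V member 1 (Homo sapiens), read by FLIPR; a lower number here means a stronger inhibitor, a higher number a weaker inhibitor:
compound 1, `CC(C(=O)NCc1ccc(C(F)(F)F)nc1-c1ccc(Cl)cc1)c1ccc(NS(C)(=O)=O)c(F)c1`, gives 0.7 nM
compound 2, `CC(C(=O)NCc1ccc(C(F)(F)F)nc1-c1ccsc1)c1ccc(NS(C)(=O)=O)c(F)c1`, gives 2 nM
compound 3, `CC(C(=O)NCc1ccc(C(F)(F)F)nc1-c1ccco1)c1ccc(NS(C)(=O)=O)c(F)c1`, gives 5.8 nM

Among these three, compound 3 is the weakest inhibitor in this assay: compound 1 is stronger by an 8.3-fold higher number from compound 1 to compound 3 (0.92 log units; beyond the scatter), and compound 2 by a 2.9-fold higher number from compound 2 to compound 3 (0.46 log units; beyond the scatter), while compound 2 itself trails compound 1 by a 2.9-fold higher number from compound 1 to compound 2 (0.46 log units; beyond the scatter). All three share the same core; they differ only in the ring attached on an aromatic carbon of the six-membered aromatic ring with one nitrogen, next to the ring nitrogen.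

Compound 4, `CC(C(=O)NCc1ccc(C(F)(F)F)nc1-n1ccnc1)c1ccc(NS(C)(=O)=O)c(F)c1`, changes that same ring again: 1H-imidazol-1-yl in place of furan-2-yl on an aromatic carbon. The group that enters is a five-membered aromatic ring with two hetero atoms and two hydrogen-bond acceptors, joined through a nitrogen. Going by the values given here, the measured steps show that each move away from the 4-chlorophenyl of compound 1 toward a smaller heteroaromatic ring gave a higher number, and the smaller two-heteroatom ring of compound 4 has no direct precedent here. A further modest weakening is therefore expected, roughly a 2.6-fold higher number from compound 3 to compound 4 (0.41 log units; beyond the scatter), though the sparse data leave the size uncertain. Compound 4 is estimated at 15 nM, most likely between 5 nM and 50 nM.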

Compound 4, inhibition constant: 36.1 nM
Compound 4: middle estimate off by 2.4-fold (0.38 log units), on the low side; measured number inside the range.
By their numbers in this assay, from the lowest: compound 1; then compound 2; then compound 3; then compound 4.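

In this assay, swapping one five-membered aromatic ring for another of the same heavy-atom count still gives a 6.2-fold higher number from compound 3 to compound 4 (0.79 log units; beyond the scatter), so the heavy-atom count of the ring does not settle the result at this position. Going by these compounds alone, the 1H-imidazol-1-yl ring is the first group here to be joined through a nitrogen and to carry two hetero atoms, and it gives the highest number of the four compounds. Within the data shown here, it also brings the first large steps, an 18-fold higher number from compound 2 to compound 4 (1.26 log units; beyond the scatter) and a 52-fold higher number from compound 1 to compound 4 (1.71 log units; beyond the scatter) in the same assay. No measurement shown here explains this loss of inhibition.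

The compounds shown leave open whether the nitrogen link or the second hetero atom accounts for the change, since compound 4 differs from compound 3 in both. A pyrrol-1-yl ring, or an imidazole joined through carbon, would help to separate the two.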